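Benzyl in Place of Cycloheptyl on the Urea Nitrogen

The source may hold more compounds than are shown below. What is called first, only, known or untested is meant among the compounds shown, and "the series" means these compounds.

Of the compounds shown here, three have been measured in a functional assay on a cell-free system (plasma) with sterol O-acyltransferase, Soat (Rattus norvegicus) as the target; on this read-out lower numbers stand for an effect already at smaller amounts and higher numbers for an effect only at larger amounts of compound. Compound 1 `Cc1cc(C)c(NC(=O)N(Cc2c[nH]c(-c3ccccc3)n2)C2CCCCCC2)c(C)c1` gives > 1 mg/kg, which is a limit of the assay rather than a number. Compound 2 `CSc1cc(C)nc(SC)c1NC(=O)N(Cc1ccccc1)Cc1ccc(-c2cc[nH]n2)cc1` gives < 0.32 mg/kg, also a limit. Compound 3 `CSc1cc(C)nc(SC)c1NC(=O)N(Cc1ccc(-c2cnn(C)c2)cc1)C1CCCCCC1` gives > 0.1 mg/kg, again a limit. Compound 3 therefore stands at the limit of > 0.1 mg/kg in this assay, at which 1 of the 3 values shown sits, and the other two values are limits as well, one at the limit of < 0.32 mg/kg in this assay, at which 1 of the 3 values shown sits, and one at the limit of > 1 mg/kg in this assay, at which 1 of the 3 values shown sits, so none of the three can be ranked against the others.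

Compound 4 `CSc1cc(C)nc(SC)c1NC(=O)N(Cc1ccccc1)Cc1ccc(-c2cnn(C)c2)cc1` has not yet been measured. It differs from compound 3 in one place: benzyl in place of cycloheptyl on an amide-type nitrogen. Compound 4 thus carries the same benzyl group on that nitrogen as compound 2, while the rest of its structure is that of compound 3. Going by the values given here, no measured pair differs only in this way, so the size of this step is not known from the data. Compound 2 gives < 0.32 mg/kg, which is a limit. On that basis the expected step that the limit leaves unreadable from compound 3 to compound 4 runs toward smaller doses, though it may fall within the scatter. Compound 4 is estimated at 0.3 mg/kg, between 0.1 mg/kg and 1 mg/kg.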

Compound 4, dose for half-maximal effect: > 0.1 mg/kg
Compound 4: a limit, no number; the forecaster's own chance of this, stated with the estimate: 40%; the middle value is on the limit's open side.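

In this assay, going by these compounds alone, compound 4 gives > 0.1 mg/kg, a limit and not a number, so no step to compound 3 or compound 2 can be read. Still open, as far as these compounds go, is how much benzyl in place of cycloheptyl on the amide-type nitrogen changes the dose.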